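Glycosylated acylhydrazones: open chain replaces nitrophenyl

This account rests on a few compounds, and the source may have more. Where it says the series, first, only, none or still open, it means among the compounds named here.

Measured so far:
compound 1 `O=C(N/N=C/C1CCCCC1)c1ccc(O[C@@H]2O[C@H](CO)[C@@H](O)[C@H](O)[C@H]2O)cc1`: 0.88%
compound 2 `O=C(N/N=C/c1cccc([N+](=O)[O-])c1)c1ccc(O[C@@H]2O[C@H](CO)[C@@H](O)[C@H](O)[C@H]2O)cc1`: 6.23%

In a functional assay on MDA-MB-231 cells (Homo sapiens) for inhibition, read by MTT assay, with a stated time of 24 h, tested at 100 uM (on this read-out lower numbers stand for less inhibition and higher numbers for more inhibition at the one concentration tested (going by the name of the read-out)), compound 1 gives 0.88% and compound 2 gives 6.23%. Compound 2 holds the higher of the two numbers, but the step of a number 5.4 percentage points higher from compound 1 to compound 2 (within the scatter) is within the scatter, so the two cannot be told apart. Compound 3 `CCCCC/C=N/NC(=O)c1ccc(O[C@@H]2O[C@H](CO)[C@@H](O)[C@H](O)[C@H]2O)cc1` differs from compound 2 by pentyl in place of 3-nitrophenyl on a carbon with a double bond to nitrogen. Among the compounds with values here, the only measured step bearing on this, a number 5.4 percentage points higher from compound 1 to compound 2 (within the scatter), also exchanged a non-aromatic group for 3-nitrophenyl and stayed within the scatter; moving back to a non-aromatic group is therefore expected to change little. Compound 3 is estimated at 2.5%, with a range from 0% to 10%. The expected step is a number 3.7 percentage points lower from compound 2 to compound 3 (within the scatter), within the scatter.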

Compound 3, a percentage reported as inhibition, at one concentration (the size of the read-out at that concentration, not a potency): 11%
The estimate for compound 3 lay 8.5 percentage points below the measured number; the whole stated range lies below it.
By their numbers in this assay, from the lowest: compounds 1, 2 and 3 (each within the scatter of the next, the first and the last beyond it).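

In this assay, within the data shown here, pentyl in place of cyclohexyl on a carbon with a double bond to nitrogen gives the first step to clear the scatter, a number 10.1 percentage points higher from compound 1 to compound 3 (beyond the scatter), though only modestly. Pentyl in place of 3-nitrophenyl at the same place gives a number 4.8 percentage points higher from compound 2 to compound 3 (within the scatter), so pentyl and 3-nitrophenyl cannot be told apart here. Nothing on hand explains the difference between pentyl and cyclohexyl.

Open, from the compounds shown here alone, is whether a longer chain such as octyl, or a shorter one such as propyl, would give a different number. Also open, going by these compounds, is what a terminal amine or carboxylic acid on the chain would give.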